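Trimming the side chain of compound 1

The compounds below may be only part of what the source reports. "The series", "measured", "known", "first", "only" and "open" are said of these compounds alone.

For the measured compounds named here, in a physicochemical assay for solubility, in phosphate buffer, at pH 7.4 (on this read-out lower numbers stand for lower solubility and higher numbers for higher solubility), compound 1 (`COc1cc(F)ccc1-c1ccnc2[nH]c(C3CCN(CC(=O)N(C)C)CC3)cc12`) gives 38000 nM, the only true number so far. Compound 2 (`CCn1cc(-c2ccnc3[nH]c(C4CCN(CC(=O)N(C)C)CC4)cc23)ccc1=O`) gives > 1000000 nM, which is a limit of the assay and not a number. Compound 1 therefore sits at the lower end of the two compounds measured. Compound 3 (`COc1cc(F)ccc1-c1ccnc2[nH]c(C3CCN(C(C)=O)CC3)cc12`) keeps the core of compound 1 and changes one group: acetyl in place of (dimethylcarbamoyl)methyl on an amine nitrogen in a ring. Going by the values given here, the one measured step, an at least 26-fold higher number from compound 1 to compound 2 (1.42 log units; beyond the scatter), is large, but it swaps a group on an aromatic carbon, which is a different place. It shows how far the read-out can move between these compounds, yet it fixes neither size nor direction here. Among the compounds with values here, no measured step touches this amine nitrogen, so a moderately lower number in this assay is only a cautious expectation, and the range stays wide. The expected step is a 3.2-fold lower number from compound 1 to compound 3 (0.50 log units; beyond the scatter). For compound 3 the estimated value is 12000 nM, with an expected range from 2500 nM to 50000 nM.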

Compound 3, solubility: 50000 nM
Estimate against measurement, compound 3: 4.2-fold (0.62 log units) below, within the range that was stated.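

In this assay, for the compounds shown here, the swap of acetyl for (dimethylcarbamoyl)methyl on the amine nitrogen in a ring is read as a 1.3-fold higher number from compound 1 to compound 3 (0.12 log units; within the scatter) and this is the first measured step at this position. Acetyl is a smaller group than (dimethylcarbamoyl)methyl, yet compound 1 and compound 3 remain indistinguishable on this read-out. The earlier step on an aromatic carbon, read as an at least 26-fold higher number from compound 1 to compound 2 (1.42 log units; beyond the scatter) and resting on a limit of the assay for compound 2, showed how far the read-out can move in this set, and this one change on the nitrogen has no such effect.

No measurement shown speaks to a cause for this result. On these data alone, it also remains open whether a different group on this nitrogen, such as a chain ending in a carboxylic acid or a longer chain ending in an amine, would move the number, and whether acetyl would behave the same way in compound 2, with its other group on the aromatic carbon.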